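A Fluoro Step Repeated on a Second Core

A few compounds are considered here, and "the series" means these few. Any claim that something is new, unique, unknown or untested is made for them only; others in the source may bear on it.

Two pairs of compounds share one structural change. Compound 2 `O=c1c(C2N=C(c3ccccc3)SS2)coc2ccccc12` and compound 1 `O=c1c(C2N=C(c3ccccc3)SS2)coc2ccc(F)cc12` differ by fluoro in place of hydrogen on an aromatic carbon. In a functional assay on A549 cells (Homo sapiens) for inhibition, read by sulforhodamine B assay, with a stated time of 48 h (a lower number here means a stronger inhibitor, a higher number a weaker inhibitor), compound 1 gives 91100 nM. Compound 2 gives only a limit in this assay, > 100000 nM. Going by these compounds, the step of an at least 1.0-fold lower number from compound 2 to compound 1 (0.04 log units; that floor lies within the scatter) therefore rests on the limit of > 100000 nM in this assay, at which 1 of the 3 values shown sits, and its true size is unknown.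

Compound 3 `O=c1c(C(=S)Nc2ccccc2)coc2ccccc12` carries a different core; how it differs from compound 2 is not broken down here. In this assay compound 3 gives 52800 nM, the lowest of the two numbers available, with compound 1 within the scatter of it.

Compound 4 `O=c1c(C(=S)Nc2ccccc2)coc2ccc(F)cc12` has not yet been measured. For the measured compounds named here, it differs from compound 3 by fluoro in place of hydrogen on an aromatic carbon, the same change as the one from compound 2 to compound 1, at an identical place. Because an at least 1.0-fold lower number from compound 2 to compound 1 (0.04 log units; that floor lies within the scatter) is only a floor that lies within the scatter, no clear shift is expected from this change. Compound 4 is therefore expected to give about 45000 nM in this assay, estimated between 20000 nM and 100000 nM. The expected step is a 1.2-fold lower number from compound 3 to compound 4 (0.07 log units; within the scatter).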

Compound 4, half-maximal inhibitory concentration: 71900 nM
Compound 4: the middle estimate sits 1.6-fold (0.20 log units) below what was measured; low and high end bracket the measured number.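

On the core of compound 3, fluoro in place of hydrogen on an aromatic carbon gives a 1.4-fold higher number from compound 3 to compound 4 (0.13 log units; within the scatter) in this assay, so on this core the change produces no clear shift. Set beside the earlier step, the two results read as follows: the same change on two cores in this assay, an at least 1.0-fold lower number (0.04 log units; that floor lies within the scatter) from compound 2 to compound 1 and a 1.4-fold higher number (0.13 log units; within the scatter) from compound 3 to compound 4; the limit leaves it open whether they differ. Going by these compounds, compound 2 gives a limit and not a number, so the size of the step on its core is unknown, and the compounds do not show whether the change acts alike or differently on the two cores: the limit of > 100000 nM in this assay, at which 1 of the 4 values shown sits.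

The compounds shown leave open whether a chloro group, a methoxy group or an amine at the same place on either core would move the number in this assay beyond the scatter. On these data alone, it also remains open how the same fluoro change would behave on a third core.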